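Adding a Second Chloro to a Fused Core

The compounds below may be only part of what the source reports. "The series", "measured", "known", "first", "only" and "open" are said of these compounds alone.

Measured so far in a functional assay on 786-0 cells (Homo sapiens) for cytotoxicity, read by sulforhodamine B assay, with a stated time of 48 h; on this read-out higher numbers stand for lower toxicity in this test and lower numbers for higher toxicity in this test:
compound 1 `ClCc1cccc(Cn2cnc3ncnc(Cl)c32)c1`, 70800 nM
compound 2 `ClCc1ccccc1Cn1cnc2ncnc(Cl)c21`, 47900 nM
compound 3 `ClCc1cccc(Cn2cnc3nc(Cl)nc(Cl)c32)c1`, 5370 nM

Compound 3 differs from compound 1 by one change, (chloro in place of hydrogen on an aromatic carbon), and this change gave a 13-fold lower number from compound 1 to compound 3 (1.12 log units; beyond the scatter). Compound 2 and compound 1 are built from the same atoms joined differently; the difference between the two cores is not broken down here. In this assay compound 2 gives 47900 nM, which is within the scatter of compound 1.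

Compound 4 `ClCc1ccccc1Cn1cnc2nc(Cl)nc(Cl)c21` is not yet measured. It differs from compound 2 by chloro in place of hydrogen on an aromatic carbon, the same change as from compound 1 to compound 3, at a place described in the same words. The step from compound 2 to compound 4 is expected to be a 12-fold lower number from compound 2 to compound 4 (1.08 log units; beyond the scatter), set beside a 13-fold lower number from compound 1 to compound 3 (1.12 log units; beyond the scatter), because it starts from compound 2 at 47900 nM. Compound 4 is therefore estimated at 4000 nM, expected between 1500 nM and 12000 nM.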

Compound 4, concentration lethal to 50% of the cells: 30900 nM
Compound 4: the middle estimate sits 7.7-fold (0.89 log units) below what was measured, and the stated range ends below it.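

In this assay, adding the same chloro to the core of compound 2 gave a 1.6-fold lower number from compound 2 to compound 4 (0.19 log units; within the scatter), so the large step seen on the core of compound 1 did not carry over. The two steps clearly differ: the same change on two cores in this assay, a 13-fold lower number (1.12 log units; beyond the scatter) from compound 1 to compound 3 and a 1.6-fold lower number (0.19 log units; within the scatter) from compound 2 to compound 4, 8.5-fold (0.93 log units) apart, beyond the scatter of two such steps

A change that works strongly on one core therefore cannot be assumed to do the same on a closely related core, at least for these two pairs. What this does not show is why the steps differ, and two pairs give no general rule for the series.

As far as these compounds go, it remains open whether an amine or a methoxy group on that same aromatic carbon would follow the larger step, the smaller one, or neither.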